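A few compounds are considered here, and "the series" means these few. Any claim that something is new, unique, unknown or untested is made for them only; others in the source may bear on it.

Three compounds built on one shared core were tested in an ADME assay on Vero cells (Chlorocebus sabaeus) for cytotoxicity, read by MTT assay, with a stated time of 72 h; a lower number here means that less compound is tolerated, a higher number that more compound is tolerated. Compound 1 `O=c1nc(N2CCN(NCc3ccc(OC(F)(F)F)cc3)CC2)sc2c([N+](=O)[O-])cc(C(F)(F)F)cc12` carries a 4-(trifluoromethoxy)benzyl group on an amine nitrogen. In this assay compound 1 reaches only a limit, > 64 ug/mL. Compound 2 `O=c1nc(N2CCN(NCc3ccc(C(F)(F)F)cc3)CC2)sc2c([N+](=O)[O-])cc(C(F)(F)F)cc12` differs from compound 1 by trifluoromethoxy in place of trifluoromethyl on an aromatic carbon. In this assay compound 2 gives only the limit > 64 ug/mL. The step that the two limits leave unreadable from compound 2 to compound 1 therefore cannot be read. Compound 3 `O=c1nc(N2CCN(Nc3ccc(C(F)(F)F)cc3)CC2)sc2c([N+](=O)[O-])cc(C(F)(F)F)cc12` differs from compound 2 in its core by 4-(trifluoromethyl)phenyl in place of 4-(trifluoromethyl)benzyl on an amine nitrogen. In this assay compound 3 stops at the limit > 64 ug/mL. Compound 4 `O=c1nc(N2CCN(Nc3ccc(OC(F)(F)F)cc3)CC2)sc2c([N+](=O)[O-])cc(C(F)(F)F)cc12` is not yet measured; it differs from compound 3 by trifluoromethoxy in place of trifluoromethyl on an aromatic carbon, the same change, at the same place, as from compound 2 to compound 1. Because (the limit of > 64 ug/mL in this assay, at which 3 of the 3 values shown sit), this change is expected to leave compound 4 at the limit as well, and the step that the limit leaves unreadable from compound 3 to compound 4 is estimated to stay unreadable in the same way. Compound 4 is expected to give 100 ug/mL in this assay.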

Compound 4, half-maximal cytotoxic concentration: > 64 ug/mL
Compound 4: only a limit was reported; the forecaster's own chance of this, stated with the estimate: 85%; the middle value is on the limit's open side.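

In this assay compound 4 gives only a limit, > 64 ug/mL. Within the data shown here, no step from compound 1, compound 2 or compound 3 to compound 4 can be read. The compounds shown leave open at what concentration any of them harms these cells.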